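Removing one methoxy group: working notes on the series

The source may report more compounds than this note shows. Statements on the series, on what has been measured and on what is new or still open speak of the compounds shown alone.

Compound 1 `COc1cccc(/C=C/C(=O)c2cccc(-c3cccc(F)c3)c2)c1OC` in a functional assay on MCF7 cells (Homo sapiens) for cytotoxicity, read by sulforhodamine B assay, with a stated time of 48 h (a higher number here means a weaker inhibitor, a lower number a stronger inhibitor), gives 11700 nM. Compound 2 `COc1ccccc1/C=C/C(=O)c1cccc(-c2cccc(F)c2)c1` differs from it by hydrogen in place of methoxy on an aromatic carbon; in this assay compound 2 gives 18900 nM, so that a 1.6-fold higher number from compound 1 to compound 2 (0.21 log units; within the scatter). Compound 3 `COc1cc(/C=C/C(=O)c2ccc(N)c(-c3ccc(F)cc3)c2)cc(OC)c1OC` rests on another core; the difference between the two cores is not broken down here. In this assay compound 3 gives 9030 nM. Compound 4 `COc1ccc(/C=C/C(=O)c2ccc(N)c(-c3ccc(F)cc3)c2)cc1OC` is not yet measured and differs from compound 3 by hydrogen in place of methoxy on an aromatic carbon. The surroundings are not identical: in compound 3 the carbon is also meta to a methoxy group, so this is the same kind of change, not the same change. Going by the values given here, with only the one earlier step to lean on, the expected step is a 1.6-fold higher number from compound 3 to compound 4 (0.19 log units; within the scatter), resting on a 1.6-fold higher number from compound 1 to compound 2 (0.21 log units; within the scatter). Compound 4 is therefore estimated at 14000 nM, expected between 6000 nM and 35000 nM.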

Compound 4, half-maximal inhibitory concentration: 15000 nM
Compound 4: the middle estimate sits 1.1-fold (0.03 log units) below what was measured; low and high end bracket the measured number.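

Replacing methoxy with hydrogen on the core of compound 3 gives a 1.7-fold higher number from compound 3 to compound 4 (0.22 log units; within the scatter) in this assay. Set beside the earlier step, the change carries over between the two cores at much the same size: the same change on two cores in this assay, a 1.6-fold higher number (0.21 log units; within the scatter) from compound 1 to compound 2 and a 1.7-fold higher number (0.22 log units; within the scatter) from compound 3 to compound 4, 1.0-fold (0.01 log units) apart, within the scatter of two such steps. Going by these compounds alone, both steps lie within the scatter, however, so the pair shows only that the change does little on either core; it does not establish a real loss of activity, and two cores do not make a rule for the series.

Going by these compounds, whether a hydroxyl or an ethoxy group at this carbon would give a larger step remains open. So does whether removing the remaining methoxy groups would give a step of similar size.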